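The source may report more compounds than this note shows. Statements on the series, on what has been measured and on what is new or still open speak of the compounds shown alone.

Measured compounds:
compound 1, `Cc1ccc2nc(Cn3c(=O)n(C4CC4)c4ccncc43)c(CCCCO)n2c1`: > 100000 nM
compound 2, `Cc1ccn2c(CCCCO)c(Cn3c(=O)n(C4CC4)c4ccncc43)nc2c1`: > 100000 nM
compound 3, `N#Cc1c(Cn2c(=O)n(C3CC3)c3ccncc32)nc2cc(Cl)ccn12`: 22500 nM

All three were tested in an ADME assay on HEp-2 cells (Homo sapiens) for cytotoxicity, read by CCK-8 assay, with a stated time of 6 days; a lower number here means that less compound is tolerated, a higher number that more compound is tolerated. For compound 1 the value > 100000 nM is a limit of the assay, not a number. For compound 2 the value > 100000 nM is likewise a limit and not a number. Among the measured compounds shown here, compound 3 thus holds the only actual number in this assay, 22500 nM, and it sits apart from the limit of > 100000 nM in this assay, at which 2 of the 3 values shown sit; since no two measured compounds differ in a single place, no measured step between them can be drawn.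

The next compound, compound 4, `CCCCNc1c(Cn2c(=O)n(C3CC3)c3ccncc32)nc2cc(Cl)ccn12`, differs from compound 3 by butylamino in place of cyano on an aromatic carbon. For the measured compounds named here, no measured pair shows the effect of such a change, so the expectation rests on compound 3 alone. Compound 4 is expected to stay close to compound 3, with a step of a 1.1-fold lower number from compound 3 to compound 4 (0.05 log units; within the scatter) that does not go beyond the usual scatter. Compound 4 is therefore estimated at 20000 nM in this assay, in a range from 6000 nM to 70000 nM.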

Compound 4, half-maximal cytotoxic concentration: > 100000 nM
Compound 4 was reported as a limit (the forecaster's own chance of this, stated with the estimate: 20%); middle value at least 5.0-fold (0.69 log units) away from the limit.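

In this assay, among the compounds shown here, butylamino in place of cyano on this aromatic carbon gives an at least 4.4-fold higher number from compound 3 to compound 4 (0.64 log units; beyond the scatter), the first measured step in the set and one that lies beyond the scatter. For the compounds shown here, this is the first sign that the group at this carbon, on the five-membered aromatic ring, can shift the read-out, though the step gives only a lower bound on the size of the change. Compound 3 remains the only compound with an actual number, and compound 4 joins compounds 1 and 2 at one shared assay limit: the limit of > 100000 nM in this assay, at which 3 of the 4 values shown sit.

Going by these compounds, how far past that limit compound 4 lies remains open, so the full size of the step cannot be told. On these data alone, it is also open where a smaller group on this carbon, such as a plain amine, methylamino or a carboxylic acid, would fall relative to cyano and butylamino.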